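A few compounds are considered here, and "the series" means these few. Any claim that something is new, unique, unknown or untested is made for them only; others in the source may bear on it.

Measured compounds:
compound 1, `C=C1/C=C/C(=O)/C(CO)=C\C[C@](C)(CCC=C(C)C)/C=C/[C@H]1OC(=O)C=C(C)C`, 2810 nM
compound 2, `CC(C)=CCC[C@]1(C)/C=C/[C@@H](OC(=O)C=C(C)C)[C@](C)(O)/C=C/C(=O)/C(CN(C(C)C)C(C)C)=C\C1`, 740 nM

In a functional assay on HL-60 cells (Homo sapiens) for antiproliferative activity, read by MTT assay, with a stated time of 48 h (a lower number here means a stronger inhibitor, a higher number a weaker inhibitor), compound 2 gives 740 nM, the lowest of the two numbers recorded so far; in this assay compound 1 gives 2810 nM, a higher number that sits beyond the scatter of the method. For the measured compounds named here, no step between the two measured compounds is recorded, since they differ in more than one place, so the comparison says only what the two values show.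

Compound 3, `CSC(=S)OC/C1=C/C[C@](C)(CCC=C(C)C)/C=C/[C@@H](OC(=O)C=C(C)C)[C@](C)(O)/C=C/C1=O`, has not yet been measured. It differs from compound 2 in one place: a group of 5 heavy atoms (2 carbon, 1 oxygen, 2 sulfur; no ring) in place of a group of 7 heavy atoms (6 carbon, 1 nitrogen; no ring), on a saturated chain carbon bound to a double-bonded ring carbon. Going by the values given here, nothing among the measured compounds shows what this exchange does, so the expectation rests on compound 2 alone.

Compound 3 is expected to remain in the range between the two measured values, probably a somewhat weaker inhibitor than compound 2, with the step of a 1.8-fold higher number from compound 2 to compound 3 (0.24 log units; within the scatter) being modest and possibly within the scatter. The estimate for compound 3 in this assay is 1300 nM, with a range from 400 nM to 4000 nM.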

Compound 3, half-maximal inhibitory concentration: 180 nM
The estimate for compound 3 lay 7.2-fold (0.86 log units) above the measured number; the whole stated range lies above it.
By their numbers in this assay, from the lowest: compound 3; then compound 2; then compound 1.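

In this assay, the saturated chain carbon bound to a double-bonded ring carbon proves to be a place where one exchange alone moves the number: replacing the diisopropylamino group with the group of 5 heavy atoms (2 carbon, 1 oxygen, 2 sulfur; no ring) gives a 4.1-fold lower number from compound 2 to compound 3 (0.61 log units; beyond the scatter) at an otherwise unchanged core. The earlier comparison could not show this, since compound 1 and compound 2 differ in more than one place, and it also shows that the nitrogen of the diisopropylamino group is not required at this position, with compound 3 reaching 180 nM without any nitrogen in the entering group. No measurement at hand accounts for the size or direction of this step.

As far as these compounds go, whether the lower number comes from the sulfur atoms, from the oxygen link or simply from the loss of the diisopropylamino group stays open, and a single exchange does not separate these readings. The compounds shown also leave unanswered how a plain acetate ester, a thiol, a morpholine or a longer chain would stand at this position.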